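A few compounds are considered here, and "the series" means these few. Any claim that something is new, unique, unknown or untested is made for them only; others in the source may bear on it.

Measured so far:
compound 1 `O=C(c1ccccc1)N1CCC(C(=O)N2N=CCC2c2ccccc2)CC1`: 1.72 h
compound 2 `CC(C)C(=O)N1N=CCC1c1ccccc1`: > 1.5 h (a limit of the assay)
compound 3 `O=C(C1CCOCC1)N1N=CCC1c1ccccc1`: > 1.5 h (a limit of the assay)

Among the compounds with values here, in an ADME assay on microsomes (Homo sapiens) for metabolic stability (a higher number here means that the compound lasts longer, a lower number that the compound disappears faster), compound 1 gives 1.72 h and holds the only true number. The other two values are limits and cannot be ranked against it: the limit of > 1.5 h in this assay, at which 2 of the 3 values shown sit.

Compound 4 `O=C(c1cc[nH]n1)N1CCC(C(=O)N2N=CCC2c2ccccc2)CC1` differs from compound 1 by one change, 1H-pyrazol-3-yl in place of phenyl on a carbonyl carbon. The rest of the structure stays the same.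

Within the data shown here, the one measured step is a step that the two limits leave unreadable from compound 2 to compound 3 and it also changes a group on a carbonyl carbon, but it offers no size to carry over. Among the measured compounds shown here, no measured step covers the replacement of phenyl by 1H-pyrazol-3-yl, so the expectation starts from compound 1 at 1.72 h and foresees no shift beyond the scatter in this assay in either direction. The expected 1.0-fold higher number from compound 1 to compound 4 (0.02 log units; within the scatter) is accordingly small. With most values in the series sitting at a limit, a limit may also be all that is reported for the new compound. The estimate for compound 4 is 1.8 h with an expected range from 0.9 h to 3.6 h.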

Compound 4, half-life: > 2.75 h
Compound 4: a limit, no number; the forecaster's own chance of this, stated with the estimate: 45%; at least 1.5-fold (0.18 log units) between middle value and limit.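

Compound 4 gives > 2.75 h in this assay, which is a limit and not a number: the limit of > 2.75 h in this assay, at which 1 of the 4 values shown sits.

Within the data shown here, at the carbonyl carbon whose other neighbour is the amide-type nitrogen in a ring, this yields the first readable step, an at least 1.5-fold higher number from compound 1 to compound 4 (0.20 log units; that floor lies within the scatter), with 1H-pyrazol-3-yl in place of phenyl, whereas the steps between limits, such as the one linking compound 2 and compound 3, cannot be read. Going by these compounds, in this one pair, the change from benzoyl to (1H-pyrazol-3-yl)carbonyl therefore gives a higher printed floor for the half-life, though the floor itself does not separate compound 4 from compound 1 beyond the scatter, and the true size of the step stays unknown.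

On these data alone, how much of the step belongs to the ring nitrogens and how much to the amide-type hydrogen of the pyrazole remains open, and a pyridyl ring or a methyl group on the pyrazole nitrogen at the same place would bear on that. Also open, as far as these compounds go, is whether the same replacement holds on a different core, since the step rests on a single pair.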